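Shortening the amine chain on a chromone sigma ligand

This account rests on a few compounds, and the source may have more. Where it says the series, first, only, none or still open, it means among the compounds named here.

Measured compounds: compound 1 `O=c1cc(-c2ccccc2)oc2cccc(OCCCCN3CCC(O)CC3)c12` gives 58 nM; compound 2 `O=c1cc(-c2ccccc2)oc2cccc(OCCCCCCCN3CCC(O)CC3)c12` gives 36 nM; compound 3 `CN(C)CCCCCCCCCCOc1ccc2oc(-c3ccccc3)cc(=O)c2c1` gives 297 nM, all in an assay on isolated protein (Cavia porcellus) with Sigma non-opioid intracellular receptor 1 (Homo sapiens) as the target, read by radioligand binding; a lower number here means a stronger inhibitor, a higher number a weaker inhibitor.

Among these three numbers compound 3 stands highest, beyond the scatter from both compound 1 and compound 2. Compound 4 `CCN(CC)CCCCCCOc1ccc2oc(-c3ccccc3)cc(=O)c2c1` differs from compound 3 by diethylamino in place of 4-(dimethylamino)butyl on a saturated chain carbon, six bonds along the chain from an oxygen on an aromatic ring. Going by the values given here, only one measured step concerns chain length: a 1.6-fold lower number from compound 1 to compound 2 (0.21 log units; within the scatter), where a longer chain between the aromatic oxygen and the amine left the number within the scatter. The change to compound 4 runs the other way, shortening the chain, and on that single step no shift beyond the scatter is expected for compound 4, that is a 1.2-fold lower number from compound 3 to compound 4 (0.07 log units; within the scatter). Compound 4 is therefore estimated at 250 nM, between 90 nM and 700 nM.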

Compound 4, half-maximal inhibitory concentration: 91 nM
Estimate against measurement, compound 4: 2.7-fold (0.44 log units) above; low and high end bracket the measured number.
By their numbers in this assay, from the lowest: compounds 2, 1 and 4 (each within the scatter of the next, the first and the last beyond it); then compound 3.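

In this assay the change from 4-(dimethylamino)butyl to diethylamino gives a 3.3-fold lower number from compound 3 to compound 4 (0.51 log units; beyond the scatter) and so moves the number beyond the scatter, which the earlier chain step, a 1.6-fold lower number from compound 1 to compound 2 (0.21 log units; within the scatter), did not do. This single change shortens the chain and also replaces the methyl groups on the nitrogen with ethyl groups, and the step cannot separate the two. Nothing available explains the shift.

Still open, on these data alone, is what dimethylamino would give on the shorter chain of compound 4. Diethylamino on the longer chain of compound 3 is equally open.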